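Chloro in place of methoxy: compound 2 to compound 3

The source may report more compounds than this note shows. Statements on the series, on what has been measured and on what is new or still open speak of the compounds shown alone.

In a functional assay on ECa-109 cells for inhibition, with ECa-109 cell line (Homo sapiens) as the target, read by sulforhodamine B assay (a higher number here means a weaker inhibitor, a lower number a stronger inhibitor), compound 1 `CCCN(CCC)C1=CC(=O)c2nc3n(c2C1=O)[C@H]1OC[C@@H](O)[C@H]1OC3` reads > 16000 nM, which is a limit. Going by the values given here, compound 2 `COc1cccc(NC2=CC(=O)c3nc4n(c3C2=O)[C@H]2OC[C@@H](O)[C@H]2OC4)c1` gives 7620 nM, the only actual number so far in this assay.

Among the compounds with values here, the single measured step is an at least 2.0-fold lower number from compound 1 to compound 2 (0.32 log units; beyond the scatter), beyond the scatter. It replaced the whole amino group, and its size rests on (the limit of > 16000 nM in this assay, at which 1 of the 2 values shown sits).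

Compound 3 `O=C1C=C(Nc2cccc(Cl)c2)C(=O)c2c1nc1n2[C@H]2OC[C@@H](O)[C@H]2OC1` has chloro in place of methoxy on an aromatic carbon. Within the data shown here, no measured step covers this smaller change, so no shift beyond the scatter is expected. The expected step is a 1.2-fold lower number from compound 2 to compound 3 (0.07 log units; within the scatter). For compound 3, the estimated value is 6500 nM, with an expected range from 2500 nM to 16000 nM.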

Compound 3, half-maximal inhibitory concentration: 4690 nM
Estimate against measurement, compound 3: 1.4-fold (0.14 log units) above, and the stated range covers the measured number.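

In this assay, chloro in place of methoxy on this aromatic carbon gives a 1.6-fold lower number from compound 2 to compound 3 (0.21 log units; within the scatter), so the hydrogen-bond acceptor of the methoxy is not needed to hold the number here. (3-Chlorophenyl)amino, like (3-methoxyphenyl)amino, stands clear of dipropylamino, with an at least 3.4-fold lower number from compound 1 to compound 3 (0.53 log units; beyond the scatter). The size of that step rests on a limit: the limit of > 16000 nM in this assay, at which 1 of the 3 values shown sits.

Still open, from the compounds shown here alone, is whether an amine or a carboxylic acid on this aromatic carbon would shift the number beyond the scatter. Also open, going by these compounds, is how a plain phenylamino group, without any group on the ring, compares.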